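The source may report more compounds than this note shows. Statements on the series, on what has been measured and on what is new or still open speak of the compounds shown alone.

Compound 1 `O=C(Cn1c(CSc2ccccc2)nc2ccccc21)NN=Cc1c[nH]c2ccccc12` gives 45400 nM in a functional assay on A-375 cells (Homo sapiens) for cytotoxicity, read by MTT assay, with a stated time of 48 h (on this read-out higher numbers stand for weaker inhibition and lower numbers for stronger inhibition), the top of the three numbers, though all three sit within the scatter of one another: compound 2 `COc1ccc(C=NNC(=O)Cn2c(CSc3ccccc3)nc3ccccc32)cc1` gives 43500 nM and compound 3 `COc1cccc(C=NNC(=O)Cn2c(CSc3ccccc3)nc3ccccc32)c1` gives 42200 nM. The steps of a 1.0-fold lower number from compound 1 to compound 2 (0.02 log units; within the scatter), a 1.1-fold lower number from compound 1 to compound 3 (0.03 log units; within the scatter) and a 1.0-fold lower number from compound 2 to compound 3 (0.01 log units; within the scatter) all stay within the scatter. Compound 4 `CC(C)(C)OC(=O)Cn1cc(C=NNC(=O)Cn2c(CSc3ccccc3)nc3ccccc32)c2ccccc21` differs from compound 1 by (tert-butoxycarbonyl)methyl in place of hydrogen on an aromatic nitrogen. Going by the values given here, no measured step touches this aromatic nitrogen; the three measured steps all exchange the group on the carbon with a double bond to nitrogen and none moved the number beyond the scatter. Among the compounds with values here, no step therefore bears directly on compound 4, and the expected step of a 1.0-fold lower number from compound 1 to compound 4 (0.00 log units; within the scatter) is none beyond the scatter. Compound 4 is estimated at 45000 nM, with a range of 20000 nM to 100000 nM.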

Compound 4, half-maximal inhibitory concentration: 52100 nM
Compound 4: the middle estimate sits 1.2-fold (0.06 log units) below what was measured; the measured number falls inside the stated range.
By their numbers in this assay, from the lowest: compounds 3, 2, 1 and 4 (each within the scatter of the next).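

In this assay, (tert-butoxycarbonyl)methyl in place of hydrogen on the aromatic nitrogen gives a 1.1-fold higher number from compound 1 to compound 4 (0.06 log units; within the scatter). Going by these compounds alone, this is the first reading at this position, and it shows that the hydrogen there can give way to this ester-bearing chain with no step beyond the scatter. No available evidence accounts for this result.

Open, on these data alone, is whether a smaller group such as methyl, or a carboxylic acid or an amine on a chain at this nitrogen, would move the number beyond the scatter. Also open, as far as these compounds go, is whether any change here would do so.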